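A few compounds are considered here, and "the series" means these few. Any claim that something is new, unique, unknown or untested is made for them only; others in the source may bear on it.

Compound 1 `Cn1cc(/C=C2/C(=O)Nc3ccccc32)c2cc(Nc3nccc(-c4ccccc4)n3)ccc21` is measured in a functional assay on MCF7 cells (Homo sapiens) for cytotoxicity, read by MTT assay, with a stated time of 48 h (a lower number here means a stronger inhibitor, a higher number a weaker inhibitor), where it gives 42900 nM. Among the compounds with a number in this assay it stands highest, though its nearest neighbour, compound 3 `Cn1cc(/C=C2/C(=O)Nc3ccccc32)c2cc(Nc3nccc(-c4ccc(O)cc4)n3)ccc21`, gives 39600 nM, and that gap, a 1.1-fold lower number from compound 1 to compound 3 (0.03 log units; within the scatter), is too small to rank the two. Compound 2 `COc1ccc(-c2ccnc(Nc3ccc4c(c3)c(/C=C3/C(=O)Nc5ccccc53)cn4C)n2)cc1` reports only a limit, > 100000 nM. That is the limit of > 100000 nM in this assay, at which 1 of the 3 values shown sits. The step of an at least 2.3-fold higher number from compound 1 to compound 2 (0.36 log units; beyond the scatter) and the step of an at least 2.5-fold lower number from compound 2 to compound 3 (0.40 log units; beyond the scatter) together show that a methoxy at this position weakened the compound while a hydroxy left it unchanged.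

Compound 4 `Cn1cc(/C=C2/C(=O)Nc3ccccc32)c2cc(Nc3nccc(-c4ccc(C(F)(F)F)cc4)n3)ccc21` differs from compound 1 by trifluoromethyl in place of hydrogen on an aromatic carbon. Within the data shown here, no measured step introduces a trifluoromethyl, so the two changes at the same place are the only guide, and they point in different directions: one within the scatter, one beyond it toward weaker inhibition. A small to modest weakening is therefore expected, a 1.4-fold higher number from compound 1 to compound 4 (0.15 log units; within the scatter). For compound 4 the expected value in this assay is 60000 nM, in a range from 25000 nM to 150000 nM.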

Compound 4, half-maximal inhibitory concentration: 65200 nM
Estimate against measurement, compound 4: 1.1-fold (0.04 log units) below, and the stated range covers the measured number.
By their numbers in this assay, from the lowest: compounds 3, 1 and 4 (each within the scatter of the next). At a limit, above all of these: compound 2.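

Trifluoromethyl, with its 4 heavy atoms and no hydrogen-bond donors or acceptors, cannot be told apart from hydrogen at this place on the ring in this assay (a 1.5-fold higher number from compound 1 to compound 4 (0.18 log units; within the scatter)). It also cannot be told apart from hydroxy (a 1.6-fold higher number from compound 3 to compound 4 (0.22 log units; within the scatter)), so these three compounds cannot be ranked, and the weakening seen with methoxy does not extend to every group larger than hydrogen here. Compound 2 gives only a limit, not a number: the limit of > 100000 nM in this assay, at which 1 of the 4 values shown sits. The step from methoxy to trifluoromethyl therefore gives only a floor (an at least 1.5-fold lower number from compound 2 to compound 4 (0.18 log units; that floor lies within the scatter)), and this does not separate the two groups.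

No group shown here gives a number clearly lower than that of compound 1. On these data alone, whether an amine, a carboxylic acid or a longer chain at this place would do so remains open, as does the effect of trifluoromethyl on another carbon of this ring.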